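The source may hold more compounds than are shown below. What is called first, only, known or untested is meant among the compounds shown, and "the series" means these compounds.

Measured: compound 1 `NCC[C@@H]1CCO[C@H](c2ccccc2)O1` gives 165 nM in an assay for displacement of a labelled ligand from Sigma non-opioid intracellular receptor 1 (Cavia porcellus), read by scintillation counting; on this read-out higher numbers stand for weaker inhibition and lower numbers for stronger inhibition; compound 2 `c1ccc(CNCC[C@@H]2CCO[C@H](c3ccccc3)O2)cc1` gives 19 nM; compound 3 `c1ccc(CNCC[C@@H]2CCOC(c3ccccc3)(c3ccccc3)O2)cc1` gives 320 nM.

Compound 2 stands lowest of the three in this assay, with compound 1 nearest and compound 3 furthest; both gaps are beyond the scatter, so compound 2 is the strongest inhibitor shown. Among the measured compounds shown here, the one measured step, an 8.7-fold lower number from compound 1 to compound 2 (0.94 log units; beyond the scatter), concerns the amine and does not bear on the present change. Compound 4 `CC[C@@]1(c2ccccc2)OCC[C@@H](CCNCc2ccccc2)O1` differs from compound 2 by ethyl in place of hydrogen on a saturated ring carbon. For the measured compounds named here, compound 3 carries a second phenyl at that same ring carbon and gives a higher number than compound 2, which is the only guide. A higher number than compound 2 is therefore expected for compound 4, estimated as a 4.2-fold higher number from compound 2 to compound 4 (0.62 log units; beyond the scatter). Compound 4 is estimated at 80 nM, range 25 nM to 300 nM.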

Compound 4, inhibition constant: 27 nM
Estimate against measurement, compound 4: 3.0-fold (0.47 log units) above; the measured number falls inside the stated range.
By their numbers in this assay, from the lowest: compounds 2 and 4 (each within the scatter of the next); then compounds 1 and 3 (each within the scatter of the next).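

In this assay, ethyl in place of hydrogen on this saturated ring carbon leaves the number essentially unchanged: a 1.4-fold higher number from compound 2 to compound 4 (0.15 log units; within the scatter). Substitution at this carbon therefore need not cost binding, as the second phenyl of compound 3 at 320 nM alone had suggested; with ethyl there, compound 4 gives 27 nM. Nothing available accounts for the different outcomes with ethyl and phenyl.

Open, from the compounds shown here alone, is how a methyl, a propyl or a longer chain at this carbon would read. Also open, going by these compounds, is whether the opposite configuration at this carbon reads the same with ethyl.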